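Replacing a bromine by methylpiperazine on a benzothiazole urea

The compounds below may be only part of what the source reports. "The series", "measured", "known", "first", "only" and "open" are said of these compounds alone.

Measured compounds:
compound 1 `CNC(=O)c1cc(Oc2ccc3nc(NC(=O)Nc4ccc(Br)cc4)sc3c2)ccn1` — 26.7%
compound 2 `CNC(=O)c1cc(Oc2ccc3nc(NC(=O)c4ccc(Cl)cc4)sc3c2)ccn1` — 18.9%
compound 3 `CNC(=O)c1cc(Oc2ccc3nc(NC(=O)c4cccc(F)n4)sc3c2)ccn1` — 12.5%

Of the compounds shown here, three sharing one core have been tested in a functional assay on SK-BR-3 cells (Homo sapiens) for inhibition, read by MTT assay, with a stated time of 2 days, tested at 10 uM; a higher number here means more inhibition of growth at the concentration tested, a lower number less inhibition of growth. Compound 1 stands highest of the three numbers; compound 2 sits nearest, a number 7.8 percentage points lower from compound 1 to compound 2 (within the scatter), and compound 3 furthest, a number 14.2 percentage points lower from compound 1 to compound 3 (beyond the scatter). Between compound 2 and compound 3 the difference is a number 6.4 percentage points lower from compound 2 to compound 3 (within the scatter). Each of these steps changes what is attached to the carbonyl carbon; none touches the substituent at the far end of the aryl group.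

Compound 4 `CNC(=O)c1cc(Oc2ccc3nc(NC(=O)Nc4ccc(N5CCN(C)CC5)cc4)sc3c2)ccn1` is the next candidate. It differs from compound 1 in one place: 4-methylpiperazin-1-yl in place of bromo on an aromatic carbon. Among the measured compounds shown here, no measured step bears on this change, since every step so far alters the carbonyl side rather than the group on the aromatic carbon of the six-membered aromatic ring of carbon only. The estimate therefore rests on the value of compound 1 alone, and the step of a number 6.7 percentage points lower from compound 1 to compound 4 (within the scatter) is expected to be small, either way, with wide uncertainty. In this assay compound 4 is estimated at 20%, within a range from 5% to 40%.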

Compound 4, percent growth inhibition at one concentration: 30.5%
Estimate against measurement, compound 4: 10.5 percentage points below; the range from low to high includes it.
By their numbers in this assay, from the lowest: compounds 3, 2, 1 and 4 (each within the scatter of the next, the first and the last beyond it).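

Among the compounds shown here, compound 4 gives the first reading at this position, on an aromatic carbon para to a large group, where every earlier step had changed the carbonyl side. In this assay the replacement of bromo by 4-methylpiperazin-1-yl gives a number 3.8 percentage points higher from compound 1 to compound 4 (within the scatter) and so stays within the scatter. A single bromine can therefore give way to a group of 7 heavy atoms, with a six-membered non-aromatic ring and 2 hydrogen-bond acceptors, without a readable shift in growth inhibition at the tested concentration, though no information is available to explain this reading.

On these data alone, it remains open whether other groups on this aromatic carbon, such as morpholine, a simple primary amine, a carboxylic acid or a longer chain ending in an amine, would also stay within the scatter or would move the number beyond it. As far as these compounds go, it is equally open whether 4-methylpiperazin-1-yl would give a similar reading on the compounds that carry an amide instead of the urea, as this change is seen on the urea of compound 1 alone.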